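Cytotoxicity notes: pyrazole amine series, step to compound 4

This account rests on a few compounds, and the source may have more. Where it says the series, first, only, none or still open, it means among the compounds named here.

Measured so far in an ADME assay on Huh-7 cells (Homo sapiens) for cytotoxicity; on this read-out lower numbers stand for higher toxicity in this test and higher numbers for lower toxicity in this test:
compound 1 `CN1CCN(CCCNCc2cn(-c3ccc(C(F)(F)F)cc3)nc2-c2ccc(C(F)(F)F)cc2)CC1` gives 2000 nM
compound 2 `Cc1ccccc1-c1nn(-c2ccc(F)c(F)c2)cc1CNCCN1CCN(C)CC1` gives > 20000 nM
compound 3 `Cc1ccccc1-c1nn(-c2ccc(F)cc2F)cc1CNCCCCO` gives > 20000 nM

Compound 2 stands at a limit of this assay and not at a number. The value of compound 3 is likewise only a limit. Among the three values, this is the limit of > 20000 nM in this assay, at which 2 of the 3 values shown sit; only compound 1 returns a number within the range of this assay, and that number is the lowest of the three, which here means the highest toxicity shown in the set.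

Compound 4 `CSc1ccc(-n2cc(CNCCN3CCN(C)CC3)c(-c3ccccc3C)n2)cc1` is not yet measured in this assay. It differs from compound 2 in one place: 4-(methylsulfanyl)phenyl in place of 3,4-difluorophenyl on an aromatic nitrogen. Going by the values given here, no pair of measured compounds differs in just this way, so no measured step speaks directly to it. With compound 2 sitting at a limit, a step of modest size towards lower numbers, or none beyond the scatter, is the expectation; a large move towards the number seen for compound 1 is not expected from the change alone. The expected step from compound 2 to compound 4 is an at least 1.4-fold lower number from compound 2 to compound 4 (0.15 log units; that floor lies within the scatter). Compound 4 is therefore estimated at 14000 nM, with a range from 5000 nM to 25000 nM, and a fair chance that the assay again returns only a limit.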

Compound 4, half-maximal cytotoxic concentration: 17000 nM
For compound 4 the middle estimate is 1.2-fold (0.08 log units) below the measured one, and the stated range covers the measured number.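

In this assay, going by these compounds alone, placing 4-(methylsulfanyl)phenyl in place of 3,4-difluorophenyl on an aromatic nitrogen gives an at least 1.1-fold lower number from compound 2 to compound 4 (0.07 log units; that floor lies within the scatter), the first step that can be read at this position. With the rest of the structure unchanged, compound 4 gives 17000 nM, so this change brings the read-out within the measurable range. No move beyond the scatter can be claimed from the floor alone. The step remains only a floor because compound 2 is a limit and not a number: the limit of > 20000 nM in this assay, at which 2 of the 4 values shown sit.

As far as these compounds go, the actual size of the step remains open, and one substitution on this aromatic nitrogen cannot show how far the outcome depends on the sulfur-bearing group rather than on the loss of the two fluorines. Also open, from the compounds shown here alone, are a phenyl bearing a nitrile or a methoxy group at this position, and whether 4-(methylsulfanyl)phenyl would give a similar read-out with a longer chain in place of the ethyl linker to the methylpiperazine.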